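The compounds below may be only part of what the source reports. "The series", "measured", "known", "first", "only" and "open" are said of these compounds alone.

Compound 1 `Oc1nc2nonc2nc1Nc1cccc(C(F)(F)F)c1` is the starting point. In an assay on mitochondria from L6 cells (Rattus norvegicus) for activation, with a stated time of 90 min (a higher number here means that more compound is needed for the effect, a lower number that less compound is needed), compound 1 gives 13300 nM. Compound 2 `Oc1nc2nonc2nc1Nc1cccc(OC(F)(F)F)c1` differs from it in one place, (trifluoromethoxy in place of trifluoromethyl on an aromatic carbon), and in this assay compound 2 gives 5100 nM, so that a 2.6-fold lower number from compound 1 to compound 2 (0.42 log units; beyond the scatter).

Compound 3 `Oc1nc2nonc2nc1Nc1ccc(C(F)(F)F)c(F)c1` has a different core; how that core differs from the core of compound 1 is not broken down here. In this assay compound 3 gives 11600 nM, a number that sits within the usual scatter of the number for compound 1.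

Compound 4 `Oc1nc2nonc2nc1Nc1ccc(OC(F)(F)F)c(F)c1` has not yet been measured. It differs from compound 3 by trifluoromethoxy in place of trifluoromethyl on an aromatic carbon. For the measured compounds named here, this is the same kind of change as the one from compound 1 to compound 2, but the surroundings are not the same: in compound 2 the new group sits meta to a large group, whereas in compound 4 it sits ortho to a fluoro group and para to a large group. Because a 2.6-fold lower number from compound 1 to compound 2 (0.42 log units; beyond the scatter), a step of similar size, a 2.6-fold lower number from compound 3 to compound 4 (0.41 log units; beyond the scatter), is expected here. For compound 4 the estimated value in this assay is 4500 nM, with a likely range from 2000 nM to 10000 nM.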

Compound 4, half-maximal effective concentration: 2900 nM
Compound 4: middle estimate off by 1.6-fold (0.19 log units), on the high side; the measured number falls inside the stated range.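

Replacing trifluoromethyl with trifluoromethoxy on the second core again gives a lower number in this assay, namely a 4.0-fold lower number from compound 3 to compound 4 (0.60 log units; beyond the scatter). Set side by side, the two steps agree: the same change on two cores in this assay, a 2.6-fold lower number (0.42 log units; beyond the scatter) from compound 1 to compound 2 and a 4.0-fold lower number (0.60 log units; beyond the scatter) from compound 3 to compound 4, 1.5-fold (0.19 log units) apart, within the scatter of two such steps. The change therefore carries over between these two cores in the same direction and with a size that cannot be told apart, so the larger-looking second step should not be read as a real difference between the cores, but two pairs cannot show that it would hold on a core further removed or explain why the number falls.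

The compounds shown compare only trifluoromethyl and trifluoromethoxy, so it remains open whether a smaller methoxy group, a chlorine atom or a nitrile would lower the number as well. Going by these compounds, it also remains open how the number would respond if an amine or a carboxylic acid took the place of the hydroxy group on the shared core.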